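Dimethylamino at the aromatic carbon of compound 1

A few compounds are considered here, and "the series" means these few. Any claim that something is new, unique, unknown or untested is made for them only; others in the source may bear on it.

Compound 1, `Fc1cc2nc(-c3cncnc3)n(C3CC3)c2cc1F`, is the reference point here. In an ADME assay on microsomes from liver (Macaca fascicularis) for metabolic stability, read by LC-MS, with a stated time of 65 min, tested at 1 uM (a lower number here means that less of the compound is left, a higher number that more of the compound is left), compound 1 gives 98%, the highest of the three numbers measured. Compound 2, `CCc1ncncc1-c1nc2cc(F)c(F)cc2n1C1CC1`, carries ethyl in place of hydrogen on an aromatic carbon and gives 78%; compound 3, `CC(C)c1ncncc1-c1nc2cc(F)c(F)cc2n1C1CC1`, carries isopropyl at that place and gives 80%.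

The change to compound 4, `CN(C)c1ncncc1-c1nc2cc(F)c(F)cc2n1C1CC1`, is dimethylamino in place of hydrogen on an aromatic carbon.

For the measured compounds named here, two measured steps bear on this. Putting a small carbon group on that aromatic carbon gave a number 20 percentage points lower from compound 1 to compound 2 (beyond the scatter) and a number 18 percentage points lower from compound 1 to compound 3 (beyond the scatter). Enlarging ethyl to isopropyl changed little, as a number 2 percentage points higher from compound 2 to compound 3 (within the scatter) shows, so the size of the group did not matter much once the hydrogen was replaced. Dimethylamino is a different kind of group, and no measured compound carries a nitrogen-containing group at this place, so the comparison is indirect. Still, the two steps from compound 1 point toward a modest fall beyond the scatter.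

Compound 4 is therefore expected to give 78%, within a range of 58% to 94%, a step of a number 20 percentage points lower from compound 1 to compound 4 (beyond the scatter) that mirrors the drops seen for compound 2 and compound 3.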

Compound 4, percent of the compound remaining: 6%
For compound 4 the middle estimate is 72 percentage points above the measured one; the measured number lies below the stated range.
By their numbers in this assay, from the lowest: compound 4; then compounds 2 and 3 (each within the scatter of the next); then compound 1.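

At this place on the aromatic ring, the identity of the new group matters far more than compounds 2 and 3 could show: in this assay, dimethylamino in place of hydrogen gives a number 92 percentage points lower from compound 1 to compound 4 (beyond the scatter). Dimethylamino also stands well apart from the two carbon groups, with a number 72 percentage points lower from compound 2 to compound 4 (beyond the scatter) when it replaces ethyl and a number 74 percentage points lower from compound 3 to compound 4 (beyond the scatter) when it replaces isopropyl, so among these compounds, replacing the hydrogen is not by itself what sets the size of the fall. Nothing available here explains why so little of compound 4 is left at the end of the assay.

The compounds shown leave open whether the large fall goes with any group joined to the ring through nitrogen or only with dimethylamino itself, since a plain amino group, a methylamino group or a pyrrolidine ring at this place could side with either result. They also leave open how a methoxy group, joined through oxygen and not through carbon or nitrogen, would compare with ethyl, isopropyl and dimethylamino.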